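Piperazine acetamides: aryl swap on the ring nitrogen

A few compounds are considered here, and "the series" means these few. Any claim that something is new, unique, unknown or untested is made for them only; others in the source may bear on it.

Measured so far:
compound 1 `O=C(CN1CCN(c2ccc(F)cn2)CC1)Nc1nc2c(o1)CCCC2` — 100 nM
compound 2 `O=C(CN1CCN(c2ccncc2)CC1)Nc1nc2c(s1)CCCC2` — > 1000 nM
compound 3 `O=C(CN1CCN(c2ccc(F)cc2)CC1)Nc1nc2c(s1)CCCCC2` — 120 nM

The three compounds share the piperazine acetamide linker and differ in the aryl on the ring nitrogen and in the fused core. In an assay on isolated protein for inhibition of long-chain fatty acid transport protein 1 (Homo sapiens), read by scintillation counting, with a stated time of 20 min (on this read-out lower numbers stand for stronger inhibition and higher numbers for weaker inhibition), compound 1 gives 100 nM and compound 3 gives 120 nM; these two sit within the scatter of each other. Compound 2 gives > 1000 nM, which is a limit of this assay and not a number. Compound 2 therefore stands at the limit of > 1000 nM in this assay, at which 1 of the 3 values shown sits, and nothing more is known of it in this assay. Compound 4 `Cc1ccc(N2CCN(CC(=O)Nc3nc4c(s3)CCCC4)CC2)cc1` is not yet measured. It differs from compound 2 by 4-methylphenyl in place of pyridin-4-yl on an amine nitrogen in a ring. Going by the values given here, no step between measured compounds is recorded, so the expectation rests on the spread: both compounds carrying a six-membered aromatic ring of carbon only on the ring nitrogen fall around the values of compound 1 and compound 3, whereas the pyridin-4-yl of compound 2 gives only the limit. The step from compound 2 to compound 4 is expected to be an at least 6.6-fold lower number from compound 2 to compound 4 (0.82 log units; beyond the scatter), toward stronger inhibition and beyond the scatter. Compound 4 is estimated at 150 nM in this assay, with a range from 50 nM to 600 nM.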

Compound 4, half-maximal inhibitory concentration: 250 nM
Compound 4: the middle estimate sits 1.7-fold (0.22 log units) below what was measured; measured number inside the range.
By their numbers in this assay, from the lowest: compounds 1 and 3 (each within the scatter of the next); then compound 4. At a limit, above all of these: compound 2.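

In this assay, going by these compounds alone, with the shared core held fixed, 4-methylphenyl in place of pyridin-4-yl on an amine nitrogen in a ring gives an at least 4.0-fold lower number from compound 2 to compound 4 (0.60 log units; beyond the scatter), the first step that changes one place only. The aryl on the ring nitrogen therefore affects this read-out by itself, which compound 1 and compound 3 could not show, as each differs from compound 2 in more than one place. The full size of the step stays unknown because compound 2 stands at a limit of the assay and not at a number: the limit of > 1000 nM in this assay, at which 1 of the 4 values shown sits.

Still open, on these data alone, is whether the step follows from losing the ring nitrogen of pyridin-4-yl or from gaining the methyl; an unsubstituted phenyl on this core would separate the two. Also open, as far as these compounds go, is how a carboxylic acid or an amine on that aromatic ring would read in this assay.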